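Lengthening the Alkoxy Chain in Two Weak Antiproliferative Compounds

This account rests on a few compounds, and the source may have more. Where it says the series, first, only, none or still open, it means among the compounds named here.

Compound 1 `CCCCOC1(c2ccc(Br)cc2)SC=C(C)n2c1noc2=O` carries a butoxy group and a bromophenyl group on its core. In a functional assay on A2780/DX3 cells (Homo sapiens) for antiproliferative activity, read by MTT assay, with a stated time of 3 days (a lower number here means a stronger inhibitor, a higher number a weaker inhibitor), compound 1 gives 78000 nM. For the measured compounds named here, its only measured partner is compound 2 `CCCCOC1(c2ccc(Cl)cc2)SC=C(C)n2c1noc2=O`, in which a chloro replaces the bromo on the aromatic ring; in this assay compound 2 gives 49000 nM. That single step, a 1.6-fold lower number from compound 1 to compound 2 (0.20 log units; within the scatter), is the whole of the measured record, and it does not separate the two compounds. On the numbers shown, compound 1 has the higher of the two, but the gap to compound 2 lies within the scatter, so no order between them can be read.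

Compound 3 `CCCCCOC1(c2ccc(Br)cc2)SC=C(C)n2c1noc2=O` differs from compound 1 by methyl in place of hydrogen on a saturated chain carbon, four bonds along the chain from an oxygen on a saturated carbon. Going by the values given here, no measured step touches this part of the molecule: the step from compound 1 to compound 2 concerns the halogen on the ring, not the chain. With nothing that bears on it, the expectation rests on compound 1 alone. Compound 3 is expected to show no step beyond the scatter, a 1.1-fold lower number from compound 1 to compound 3 (0.05 log units; within the scatter). The estimate for compound 3 is 70000 nM, within a range from 25000 nM to 200000 nM.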

Compound 3, half-maximal inhibitory concentration: > 100000 nM
Compound 3: only a limit was reported (the forecaster's own chance of this, stated with the estimate: 20%); at least 1.4-fold (0.15 log units) between middle value and limit.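

In this assay compound 3 gives > 100000 nM, which is a limit of the assay and not a number. Placing methyl in place of hydrogen on a saturated chain carbon, four bonds along the chain from an oxygen on a saturated carbon, gives an at least 1.2-fold higher number from compound 1 to compound 3 (0.10 log units; that floor lies within the scatter), so this is the first reading at the chain; it shows no gain in strength from the added methyl, while its floor is too small to establish a loss. The true size of the step stays unknown because compound 3 is known only through a limit: the limit of > 100000 nM in this assay, at which 1 of the 3 values shown sits.

As far as these compounds go, what happens at this position with a shorter chain, such as an ethyl or propyl group in place of the butyl, or with a chain ending in an amine or a carboxylic acid, stays open. Also open is how the longer chain would read with chloro in place of bromo on the aromatic carbon, since the only halogen step shown, between compound 1 and compound 2, lies within the scatter.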